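The compounds below may be only part of what the source reports. "The series", "measured", "known", "first", "only" and "open" are said of these compounds alone.

Measured in a functional assay on HEK293 cells for agonist activity at G-protein coupled receptor 39 (Homo sapiens), read by scintillation proximity assay and inositol phosphate accumulation, with a stated time of 75 min, in the presence of a further agent that is not named here; on this read-out lower numbers stand for an effect already at smaller amounts and higher numbers for an effect only at larger amounts of compound:

compound 1 `Cc1nn(-c2ncnc3nc[nH]c23)c2c1C(OCc1ccccc1F)CC(=O)N2` gives 4 nM
compound 2 `CCCCCCCCOC1CC(=O)Nc2c1c(C)nn2-c1ncnc2nc[nH]c12` gives 8 nM
compound 3 `Cc1nn(-c2ncnc3nc[nH]c23)c2c1C(OCCn1nccc1C)CC(=O)N2` gives 10 nM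

Compound 3 stands at the upper end of these three numbers in this assay. Its separation from compound 2 is small, a 1.3-fold higher number from compound 2 to compound 3 (0.10 log units; within the scatter), so no order between those two can be read; its separation from compound 1 is larger, a 2.5-fold higher number from compound 1 to compound 3 (0.40 log units; beyond the scatter).

Compound 4 `Cc1nn(-c2ncnc3nc[nH]c23)c2c1C(OCc1ccc(F)cc1)CC(=O)N2` differs from compound 3 in one place: 4-fluorophenyl in place of (5-methyl-1H-pyrazol-1-yl)methyl on a saturated chain carbon bound to an oxygen on a saturated carbon. For the measured compounds named here, the step that bears on this change is the one from compound 1 to compound 3, which runs the same exchange in the opposite sense but with a 2-fluorophenyl rather than a 4-fluorophenyl group; it was a modest rise, a 2.5-fold higher number from compound 1 to compound 3 (0.40 log units; beyond the scatter). Going by the values given here, no measured pair compares a 2-fluorophenyl with a 4-fluorophenyl group, so how far the two fluorophenyl groups track each other is unknown. Compound 4 is therefore expected to give a modestly lower number than compound 3 in this assay, a 2.0-fold lower number from compound 3 to compound 4 (0.30 log units; within the scatter), with an estimate for compound 4 of 5 nM, in the range 2 nM to 15 nM.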

Compound 4, half-maximal effective concentration: 1 nM
The estimate for compound 4 lay 5.0-fold (0.70 log units) above the measured number; measured number below the stated range.
By their numbers in this assay, from the lowest: compound 4; then compounds 1, 2 and 3 (each within the scatter of the next, the first and the last beyond it).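

In this assay, for the compounds shown here, the place on a saturated chain carbon bound to an oxygen on a saturated carbon proves more responsive than the earlier compounds showed: the 4-fluorophenyl group brings a 10-fold lower number from compound 3 to compound 4 (1.00 log units; beyond the scatter) and an 8.0-fold lower number from compound 2 to compound 4 (0.90 log units; beyond the scatter) in exchange for the pyrazole-bearing and heptyl groups. Going by these compounds alone, the site of the fluorine on the phenyl ring also matters here, a point the earlier compounds could not address, since 4-fluorophenyl in place of 2-fluorophenyl gives a 4.0-fold lower number from compound 1 to compound 4 (0.60 log units; beyond the scatter) and so the two fluorophenyl groups do not track each other. Nothing given here accounts for these steps.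

Whether the gain belongs to fluorine itself stays open, as an unsubstituted phenyl, a 4-chlorophenyl or a 4-methoxyphenyl group does not appear among these compounds. How an amine or a carboxylic acid on the chain at this place would fare is also unknown.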